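The source may hold more compounds than are shown below. What is called first, only, known or untested is meant among the compounds shown, and "the series" means these compounds.

In a functional assay on the whole organism with Mus musculus as the target (on this read-out lower numbers stand for an effect already at smaller amounts and higher numbers for an effect only at larger amounts of compound), compound 1 (`CCCN1C(=O)CCC1(O)c1cccc(C(F)(F)F)c1`) gives 200 mg/kg as a number. Compound 2 (`CCCCN1C(=O)CCC1(O)c1cccc(C(F)(F)F)c1`) returns only a limit, > 200 mg/kg in this reading. Compound 3 (`CC(C)NC(=O)CCC(=O)c1cccc(C(F)(F)F)c1`) also returns only a limit, > 200 mg/kg here, and so stands at the limit of > 200 mg/kg in this assay, at which 2 of the 3 values shown sit, with no number of its own. Compound 4 (`CC(C)CNC(=O)CCC(=O)c1cccc(C(F)(F)F)c1`) carries isobutyl in place of isopropyl on an amide-type nitrogen, a change counted as isobutyl in place of isopropyl on an amide-type nitrogen in full. Going by the values given here, the only measured step, a number no lower from compound 1 to compound 2 (the limit leaves the size open) on the core of compound 1, lies at another place and its size cannot be read. The expected step, a step that the limit leaves unreadable from compound 3 to compound 4 in this assay, is therefore none beyond the usual scatter. For compound 4 the estimate is 250 mg/kg as the expected value, with 120 mg/kg to 500 mg/kg as its expected range.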

Compound 4, dose for half-maximal effect: > 200 mg/kg
Compound 4 ended at the assay's limit (the forecaster's own chance of this, stated with the estimate: 60%); the middle value does not contradict the limit.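

No step from compound 3 to compound 4 can be read, since both stand at the same limit: the limit of > 200 mg/kg in this assay, at which 3 of the 4 values shown sit.

The compounds shown leave open whether isobutyl and isopropyl on an amide-type nitrogen differ at all in this assay.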